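The compounds below may be only part of what the source reports. "The series", "measured", "known", "first", "only" and "open" are said of these compounds alone.

In a functional assay on MCF7 cells (Homo sapiens) for cytotoxicity, read by MTT assay, with a stated time of 48 h (a lower number here means a stronger inhibitor, a higher number a weaker inhibitor), compound 1 `COc1cccc(NC(=O)COc2ccc(C3C(C#N)=C(N)Oc4[nH]nc(C)c43)cc2)c1` gives 38500 nM. Compound 2 `Cc1ccc(C)c(C(=O)C2=C(O)C(=O)N(Cc3ccco3)C2c2cccnc2)c1` returns only a limit in this assay, > 200000 nM, and not a number. Compound 3 `COc1ccc(-n2c(SCC(=O)Nc3cccc(C(C)=O)c3)nnc2-c2ccccc2OC)cc1` likewise returns only a limit, > 200000 nM. Compound 2 thus stands at the edge of what this assay reports; the limit of > 200000 nM in this assay, at which 2 of the 3 values shown sit, marks where it sits. For the measured compounds named here, no step between two measured compounds is on record, so nothing here tells how much a single change can move the read-out. Compound 4 `CCOc1cccc(C(=O)C2=C(O)C(=O)N(Cc3ccco3)C2c2cccnc2)c1` differs from compound 2 by 3-ethoxyphenyl in place of 2,5-dimethylphenyl on a carbonyl carbon. With compound 2 giving only a limit, there is no foothold for a direction, and the expected step of a number no higher from compound 2 to compound 4 (the limit leaves the size open) is none beyond the usual scatter. Compound 4 is accordingly expected to give about 200000 nM, with a range from 50000 nM to 800000 nM, and is more likely than not to return only a limit again in this assay.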

Compound 4, half-maximal inhibitory concentration: 181000 nM
The estimate for compound 4 lay 1.1-fold (0.04 log units) above the measured number; the measured number falls inside the stated range.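

In this assay, the carbonyl carbon position now has a readable number, since compound 4 gives 181000 nM. Compound 2 remains at the edge of what is reported, as a limit and not a number: the limit of > 200000 nM in this assay, at which 2 of the 4 values shown sit. Going by these compounds, the change of 2,5-dimethylphenyl to 3-ethoxyphenyl gives an at least 1.1-fold lower number from compound 2 to compound 4 (0.04 log units; that floor lies within the scatter), so it shows no shift that can be told from the scatter, and the true size of the step stays open.

The compounds shown leave open whether any group on this carbonyl carbon can bring the number well away from that edge, and whether the ethoxy group or the absence of the two methyl groups counts for more. An amine or a carboxylic acid on the phenyl ring, or a chain longer than ethoxy, would bear on both questions.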